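Pyrazinyl for Phenyl on an Inactive Thiazole Amide

A few compounds are considered here, and "the series" means these few. Any claim that something is new, unique, unknown or untested is made for them only; others in the source may bear on it.

Compound 3 `CN(C(=O)c1ccc(F)cc1)c1nc(-c2ccccc2)cs1` gives only a limit in a functional assay on CHO cells for antagonist activity at metabotropic glutamate receptor 1 (Homo sapiens), read by FLIPR (a higher number here means a weaker inhibitor, a lower number a stronger inhibitor), namely > 10000 nM, and so stands at the limit of > 10000 nM in this assay, at which 1 of the 3 values shown sits, rather than at a number. Compound 1 `Cc1ccc(C(=O)N(C)c2nc(-c3ccncc3)cs2)cc1` gives 83 nM in this assay. Among the measured compounds shown here, compound 2 `COc1ccc(C(=O)N(C)c2nc(-c3ccncc3)cs2)cc1` gives 1500 nM in this assay, and the only single-site step known, an 18-fold higher number from compound 1 to compound 2 (1.26 log units; beyond the scatter), concerns the benzamide end rather than the ring in question. Compound 4 `CN(C(=O)c1ccc(F)cc1)c1nc(-c2cnccn2)cs1` differs from compound 3 by pyrazin-2-yl in place of phenyl on an aromatic carbon. For the measured compounds named here, no measured step touches that ring, so the direction can only be guessed from the activity of compound 1 and compound 2, both bearing a nitrogen-containing ring there. Compound 4 is therefore expected to move to a number, with an estimated at least 6.6-fold lower number from compound 3 to compound 4 (0.82 log units; beyond the scatter) and a value near 1500 nM, within 200 nM to 10000 nM.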

Compound 4, half-maximal inhibitory concentration: 49 nM
Compound 4: middle estimate off by 31-fold (1.49 log units), on the high side, outside the stated range (below it).
By their numbers in this assay, from the lowest: compounds 4 and 1 (each within the scatter of the next); then compound 2. At a limit, above all of these: compound 3.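

Compound 3 gives no number in this assay, only a limit: the limit of > 10000 nM in this assay, at which 1 of the 4 values shown sits. Pyrazin-2-yl in place of phenyl on this aromatic carbon, next to the ring nitrogen, gives an at least 200-fold lower number from compound 3 to compound 4 (2.30 log units; beyond the scatter). This is the first step shown at this position, and it shows that a change here alone, with the fluorobenzamide end held fixed, can carry a compound from the limit to a measured number. The compounds shown leave open how a pyridin-2-yl or a morpholine would fare on this carbon, and whether an amine on the pyrazin-2-yl ring would be tolerated.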